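The source may hold more compounds than are shown below. What is called first, only, known or untested is meant among the compounds shown, and "the series" means these compounds.

- compound 1 `CC1=C(CCc2ccoc2)[C@@]2(C)CCC(=O)C(C)(C)C2=C(O)C1=O` gives > 50000 nM as a limit
- compound 2 `CC1=C(CCc2ccoc2)[C@@]2(C)CCCC(C)(C)[C@@H]2[C@H](O)C1=O` gives > 50000 nM as a limit

In a functional assay on RAW264.7 cells (Mus musculus) for inhibition, read by Griess assay, with stated times of 2 h and 18 h (a higher number here means a weaker inhibitor, a lower number a stronger inhibitor), compound 1 gives > 50000 nM as a limit of the assay, not a number. Compound 1 therefore stands at the limit of > 50000 nM in this assay, at which 2 of the 2 values shown sit, and has no exact figure.

Compound 3 `CCOC1CC(O)(CCC2=C(C)C(=O)C(O)=C3C(C)(C)C(=O)CC[C@]23C)CO1` has not yet been measured. The change 5-ethoxy-3-hydroxyoxolan-3-yl in place of furan-3-yl on a saturated chain carbon, two bonds along the chain from a double-bonded ring carbon puts 5-ethoxy-3-hydroxyoxolan-3-yl in place of furan-3-yl on a saturated chain carbon, two bonds along the chain from a double-bonded ring carbon. For the measured compounds named here, no measured step between two compounds serves as a guide here. In this assay I expect no step beyond the scatter, or at most a small one toward a stronger inhibitor. For compound 3 the estimated value of 45000 nM comes with an expected range from 15000 nM to 100000 nM and may well prove to be a limit again. This estimate means an at least 1.1-fold lower number from compound 1 to compound 3 (0.04 log units; that floor lies within the scatter) and remains only an expectation.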

Compound 3, half-maximal inhibitory concentration: 22900 nM
The estimate for compound 3 lay 2.0-fold (0.29 log units) above the measured number; the range from low to high includes it.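

For the compounds shown here, compound 3 is the first compound here with an exact figure in this assay, so it shows that the group at the end of this chain can shift the read-out, which compounds held at a limit could not show. Placing 5-ethoxy-3-hydroxyoxolan-3-yl in place of furan-3-yl gives a measurable change (see an at least 2.1-fold lower number from compound 1 to compound 3 (0.33 log units; beyond the scatter)) in the direction of a stronger inhibitor. The true size of this step stays unknown, since compound 1 has only a limit and not a number: the limit of > 50000 nM in this assay, at which 2 of the 3 values shown sit.

The compounds shown leave open which part of the new group matters, as the hydroxy group, the ethoxy group and the loss of the furan ring all change together in compound 3. They also leave open what an amine, a carboxylic acid or a longer chain would do at this place.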